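Inverting the Stereocentres of Compound 2

This account rests on a few compounds, and the source may have more. Where it says the series, first, only, none or still open, it means among the compounds named here.

In a physicochemical assay for solubility, read by nephelometry, measured as kinetic solubility (a higher number here means a more soluble compound, a lower number a less soluble compound), compound 1 (`CC(=O)Nc1cnc2[nH]c(=O)n([C@H]3CC[C@@H](C(C)C)CC3)c(=O)c2c1`) gives 15000 nM and compound 2 (`CC(C)[C@H]1CC[C@H](n2c(=O)[nH]c3ncc(N)cc3c2=O)CC1`) gives 25000 nM so the two stand within the scatter of each other. Compound 3 (`CC(C)[C@H]1CC[C@@H](n2c(=O)[nH]c3ncc(N)cc3c2=O)CC1`) has not yet been measured. Its difference from compound 2 is the two compounds have the same atoms and bonds and differ only in configuration as drawn: 2 of 2 stereo elements differ (all stereocentres are inverted: mirror images); a stereocentre at a saturated ring carbon is drawn r in compound 2 and s in compound 3; a stereocentre at a saturated ring carbon is drawn r in compound 2 and s in compound 3 and nothing more: the two have the same atoms and bonds and differ only in configuration as drawn, with all stereocentres inverted. Among the measured compounds shown here, no measured pair shows such a change, so the expectation rests on compound 2 at 25000 nM alone. The expected 1.1-fold lower number from compound 2 to compound 3 (0.06 log units; within the scatter) stays within the scatter, in no firm direction. Compound 3 is estimated at 22000 nM within 9000 nM to 50000 nM as its expected range.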

Compound 3, solubility: 17000 nM
Compound 3: the middle estimate sits 1.3-fold (0.11 log units) above what was measured, within the range that was stated.
By their numbers in this assay, from the lowest: compounds 1, 3 and 2 (each within the scatter of the next).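

In this assay, inverting both stereocentres gives a 1.5-fold lower number from compound 2 to compound 3 (0.17 log units; within the scatter), so the configuration at these saturated ring carbons has no firm effect on the read-out. The comparison tests a single feature because of how the pair is built: the fact that compounds 2 and 3 differ only in the configuration as drawn Hydrogen in place of acetyl on a nitrogen on an aromatic ring gives a 1.1-fold higher number from compound 1 to compound 3 (0.05 log units; within the scatter), so this change also leaves the number within the scatter. The compounds shown leave open whether a longer acyl chain or a carboxylic acid in place of that acetyl would give a step beyond the scatter.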